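A few compounds are considered here, and "the series" means these few. Any claim that something is new, unique, unknown or untested is made for them only; others in the source may bear on it.

Compound 1 `CCOC(=O)c1ccc(-c2ccc(N(C)C)nn2)cc1` is tested in an ADME assay on cells (Fibroblast, Homo sapiens) for antiproliferative activity, with a stated time of 48 h; a lower number here means a stronger inhibitor, a higher number a weaker inhibitor. In this assay, compound 1 gives > 25000 nM, which is a limit of the assay and not a number. Compound 2 `COC(=O)c1ccc(-c2ccc(N(C)C)nn2)cc1` gives > 25000 nM, which is also a limit. The evidence so far is therefore (the limit of > 25000 nM in this assay, at which 2 of the 2 values shown sit).

Compound 3 `CCCCOc1ccc(-c2ccc(C(=O)OCC)cc2)nn1` keeps the ethyl ester of compound 1 and changes the other end of the molecule: butoxy replaces dimethylamino on an aromatic carbon, (butoxy in place of dimethylamino on an aromatic carbon). Among the measured compounds shown here, the only measured step is a step that the two limits leave unreadable from compound 1 to compound 2. It lies at the ester rather than at the site of this change, and it gives no size to carry over. With no measured number to build on, no clear gain in this assay is expected, and a reading at the limit is quite possible. The expected change is a number no higher from compound 1 to compound 3 (the limit leaves the size open). For compound 3 the estimated value is 25000 nM, with an expected range from 8000 nM to 50000 nM.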

Compound 3, half-maximal inhibitory concentration: > 25000 nM
Compound 3: only a limit was reported; the forecaster's own chance of this, stated with the estimate: 65%; the middle value sits exactly at the limit.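

Compound 3 gives > 25000 nM in this assay, which is a limit and not a number, so no step can be read between compound 1 and compound 3. The compounds shown leave open whether changing either end of the molecule alters activity at all: the limit of > 25000 nM in this assay, at which 3 of the 3 values shown sit.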